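A few compounds are considered here, and "the series" means these few. Any claim that something is new, unique, unknown or untested is made for them only; others in the source may bear on it.

Measured so far in a functional assay on CWR22R cells (Homo sapiens) for antiproliferative activity, read by propidium iodide staining, with a stated time of 96 h; on this read-out higher numbers stand for weaker inhibition and lower numbers for stronger inhibition:
- compound 1 `CC(O)(CSc1ccc(F)cc1)C(=O)Nc1cccc(S(F)(F)(F)(F)F)c1` gives 30200 nM
- compound 2 `CC(O)(COc1ccccc1C(F)(F)F)C(=O)Nc1cccc(S(F)(F)(F)(F)F)c1` gives 34900 nM
- compound 3 `CC(O)(COc1ccc(C#N)cc1)C(=O)Nc1cccc(S(F)(F)(F)(F)F)c1` gives 32500 nM

Compound 3 stands level with the other two compounds, and both steps that reach it stay within the scatter: a 1.1-fold higher number from compound 1 to compound 3 (0.03 log units; within the scatter) and a 1.1-fold lower number from compound 2 to compound 3 (0.03 log units; within the scatter). Compound 4 `CC(O)(COc1ccc(C#N)cc1C(F)(F)F)C(=O)Nc1cccc(S(F)(F)(F)(F)F)c1` carries a trifluoromethyl in place of hydrogen on an aromatic carbon of compound 3, ortho to a large group and meta to a cyano group (trifluoromethyl in place of hydrogen on an aromatic carbon). Going by the values given here, no measured step adds this group directly. The swap of 2-(trifluoromethyl)phenyl for 4-cyanophenyl, seen in a 1.1-fold lower number from compound 2 to compound 3 (0.03 log units; within the scatter), is the closest evidence, so no shift beyond the scatter is expected in this assay. The estimated step is a 1.2-fold lower number from compound 3 to compound 4 (0.06 log units; within the scatter) and it stays small. Compound 4 is expected at 28000 nM, with an estimated range of 12000 nM to 55000 nM for its value.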

Compound 4, half-maximal inhibitory concentration: 18300 nM
For compound 4 the middle estimate is 1.5-fold (0.18 log units) above the measured one, and the stated range covers the measured number.
By their numbers in this assay, from the lowest: compounds 4, 1, 3 and 2 (each within the scatter of the next).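

In this assay, trifluoromethyl in place of hydrogen, ortho to a large group and meta to a cyano group, gives a 1.8-fold lower number from compound 3 to compound 4 (0.25 log units; within the scatter). Cyano in place of hydrogen on an aromatic carbon gives a 1.9-fold lower number from compound 2 to compound 4 (0.28 log units; within the scatter), so the ring carries both groups together with neither step leaving the scatter. Nothing at hand accounts for these steps. The compounds shown leave open whether a smaller group such as methyl or chlorine, or an amine, at this position would move the number beyond the scatter. They also leave open how the sulfanyl link would behave with this pair of groups.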